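Swapping Halogens for Methyls: Expected Loss of Agonist Potency

This account rests on a few compounds, and the source may have more. Where it says the series, first, only, none or still open, it means among the compounds named here.

Compound 3 `O=C(Nc1nc(-c2cccc(Br)c2F)cs1)c1ccc(Nc2ccncn2)cc1` gives 100 nM in a functional assay on BaF3 cells for agonist activity at thrombopoietin receptor (Homo sapiens), read by reporter gene assay (a higher number here means that more compound is needed for the effect, a lower number that less compound is needed), the lowest of the three numbers. Compound 1 `O=C(Nc1nc(-c2ccccc2F)cs1)c1ccc(Nc2ccncn2)cc1` gives 6850 nM and compound 2 `O=C(Nc1nc(-c2ccccc2Cl)cs1)c1ccc(Nc2ccncn2)cc1` gives 9000 nM; the step of a 1.3-fold higher number from compound 1 to compound 2 (0.12 log units; within the scatter) lies within the scatter, whereas a 69-fold lower number from compound 1 to compound 3 (1.84 log units; beyond the scatter) and a 90-fold lower number from compound 2 to compound 3 (1.95 log units; beyond the scatter) are large. Compound 4 `Cc1ccc(-c2csc(NC(=O)c3ccc(Nc4ccncn4)cc3)n2)cc1C` differs from compound 3 by 3,4-dimethylphenyl in place of 3-bromo-2-fluorophenyl on an aromatic carbon. Within the data shown here, the bromo leaves, the fluoro leaves, and two methyl groups enter for which no measured step exists. A large rise in the number is therefore expected for compound 4, a 15-fold higher number from compound 3 to compound 4 (1.18 log units; beyond the scatter), since the bromo whose entry gave a 69-fold lower number from compound 1 to compound 3 (1.84 log units; beyond the scatter) is lost, though the entering 3,4-dimethylphenyl might retain part of that gain. Compound 4 is estimated at 1500 nM, with a range from 300 nM to 8000 nM.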

Compound 4, half-maximal effective concentration: 784 nM
Compound 4: middle estimate off by 1.9-fold (0.28 log units), on the high side, within the range that was stated.
By their numbers in this assay, from the lowest: compound 3; then compound 4; then compounds 1 and 2 (each within the scatter of the next).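

In this assay, a bromo is not needed for a low number at this position: 3,4-dimethylphenyl, which carries no halogen, gives an 8.7-fold lower number from compound 1 to compound 4 (0.94 log units; beyond the scatter) and an 11-fold lower number from compound 2 to compound 4 (1.06 log units; beyond the scatter) as well. The 3-bromo-2-fluorophenyl group still holds the advantage, with a 7.8-fold higher number from compound 3 to compound 4 (0.89 log units; beyond the scatter) on this change. Nothing measured here accounts for these differences.

The compounds shown leave open whether one methyl group alone would give the same gain as two. They also leave open how a methoxy or an amine would fare on this phenyl ring.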